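Intrinsic activity of the series: compound 1 and its methyl analogue

A few compounds are considered here, and "the series" means these few. Any claim that something is new, unique, unknown or untested is made for them only; others in the source may bear on it.

Compound 1 `Cc1nc(N)sc1CCCN/C(N)=N/C(=O)NC(C)c1ccccc1F` is the reference point here. Going by the values given here, in a functional assay on Right cardiac atrium for agonist activity at histamine H2 receptor (Cavia porcellus), with a stated time of 30 min, in the presence of a further agent that is not named here (on this read-out higher numbers stand for larger maximal responses and lower numbers for smaller maximal responses), compound 1 gives 0.93, the higher of the two numbers so far. Among the compounds with values here, the other measured member, compound 2 `Cc1nc(N)sc1CCCN/C(N)=N/C(=S)N[C@@H](C)c1ccccc1`, gives 0.65 in this assay, a number lower than that of compound 1 by more than the usual scatter; no single-point step links the two, so only the two values themselves can be compared. Compound 3 `Cc1ccc(C(C)NC(=O)/N=C(\N)NCCCc2sc(N)nc2C)cc1` is not yet measured in this assay. It differs from compound 1 by 4-methylphenyl in place of 2-fluorophenyl on a saturated chain carbon bound to an amide-type nitrogen and a saturated chain carbon; the rest of the shared core is unchanged. Within the data shown here, no measured pair shows this kind of exchange, so its effect is unknown from the present data. Given that compound 1 reaches 0.93, the maximal response of compound 3 is expected to remain close to it, with at most a small downward step, since the change is confined to the group on the saturated chain carbon. The expected step a number 0.080 lower from compound 1 to compound 3 (within the scatter) is therefore small, within or just beyond the scatter. Compound 3 is expected to give 0.85, in the range 0.65 to 1.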

Compound 3, intrinsic activity: the largest response reached, as a fraction of the reference agonist's: 0.85
Compound 3: the middle estimate sits on the measured number at the digits printed; the measured number falls inside the stated range.
By their numbers in this assay, from the lowest: compound 2; then compounds 3 and 1 (each within the scatter of the next).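

Going by these compounds alone, the first exchange at a single place, 4-methylphenyl in place of 2-fluorophenyl on a saturated chain carbon bound to an amide-type nitrogen and a saturated chain carbon, reads in this assay as a number 0.080 lower from compound 1 to compound 3 (within the scatter). At this position, then, the 2-fluorophenyl group of compound 1 is not needed for a high maximal response: with 4-methylphenyl, compound 3 gives 0.85, a number not separated from that of compound 1 by this read-out. No measurement of any property of the two groups bears on this result, so the data give no account of it.

A single exchange changes both the substituent and its printed place on the phenyl ring, so plain phenyl, 2-methylphenyl or 4-fluorophenyl at the same carbon would be needed to tell these two apart, and a pyridine ring or a cyclohexyl group would show whether a carbon-only aromatic ring is required at all. Also open, on these data alone, is whether the same holds for potency, as the values here describe maximal response only.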